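The source may hold more compounds than are shown below. What is called first, only, known or untested is meant among the compounds shown, and "the series" means these compounds.

In a functional assay on NCI-H358 cells (Homo sapiens) for cytotoxicity, read by sulforhodamine B assay (on this read-out higher numbers stand for an effect only at larger amounts of compound and lower numbers for an effect already at smaller amounts), compound 2 `CCCCCCCCCCCCC/C=C/[C@@H](O)[C@H](CO)n1cc(CCCCCCCCCCCCC)nn1` has no numerical value. Compound 2 gives > 50000 nM, which is a limit of the assay and not a number. Compound 3 `CCCCCCCCCCCCC/C=C/[C@@H](O)[C@H](CO)n1cc(CCCCCCCCCCCCCCCCCCCCCCCC)nn1` gives > 50000 nM, and this too is only a limit. So the position of compound 2 is bounded on one side, and how far it lies beyond that limit is unknown.

The next structure, compound 4 `CCCCCCCCCCCCC/C=C/[C@@H](O)[C@H](CO)n1cc(CCCC)nn1`, is reached by hydrogen in place of nonyl on a saturated chain carbon, four bonds along the chain from an aromatic carbon.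

Going by the values given here, only one measured step bears on this change of chain length, a step that the two limits leave unreadable from compound 2 to compound 3. It offers neither a size nor a direction to carry over. Among the compounds with values here, the only numerical value in this set belongs to compound 1 `CCCCCCCCCCCCCC[C@@H](O)[C@@H](O)[C@H](CO)n1cc(CCCC)nn1`, which gives 12900 nM in this assay. Within the data shown here, compound 4 would have the same short chain as compound 1, so the expectation leans on compound 1 with its single value of 12900 nM and remains tentative. A move towards lower numbers is therefore expected, meaning an effect at smaller amounts, and the estimate is an at least 3.1-fold lower number from compound 2 to compound 4 (0.49 log units; beyond the scatter). For compound 4 the expected value is 16000 nM, with an estimated range of 6000 nM to 45000 nM.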

Compound 4, half-maximal effective concentration: 13600 nM
The estimate for compound 4 lay 1.2-fold (0.07 log units) above the measured number; the measured number falls inside the stated range.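

In this assay the change to hydrogen in place of nonyl, on a saturated chain carbon, four bonds along the chain from an aromatic carbon, gives an at least 3.6-fold lower number from compound 2 to compound 4 (0.56 log units; beyond the scatter), which shows that the length of this chain does bear on the read-out. The earlier pair could not show this: the step between compound 2 and compound 3 cannot be read, as both of their values are limits, so it gave neither a size nor a direction. The new step is a lower bound on the size and not the size itself because compound 2 carries only a limit: the limit of > 50000 nM in this assay, at which 2 of the 4 values shown sit.

The compounds shown leave open whether the number changes gradually with chain length or only once the chain passes some length, as nothing lies in the stretch between the chains of compound 4 and compound 2. Also open, going by these compounds, is what a chain ending in an amine or a carboxylic acid would give at this place, and whether the same shortening holds on the core of compound 1 , which gives 12900 nM in this assay.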